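A few compounds are considered here, and "the series" means these few. Any claim that something is new, unique, unknown or untested is made for them only; others in the source may bear on it.

Measured so far in a functional assay on HCT-116 cells (Homo sapiens) for inhibition, read by colorimetric assay, with a stated time of 3 days; on this read-out higher numbers stand for weaker inhibition and lower numbers for stronger inhibition:

Compound 1 `O=C(CCCCCCNC(=O)C(O)(O)C(F)(F)F)Nc1cccc(Br)c1` gives 3060 nM.
Compound 2 `O=C(CCCCCCNC(=O)C(O)(O)C(F)(F)F)Nc1ccc(F)cc1` gives 7570 nM.
Compound 3 `COc1ccc(NC(=O)CCCCCCNC(=O)C(O)(O)C(F)(F)F)cc1` gives 4520 nM.

Compound 3 holds the second highest of the three numbers, but it is not separated from either neighbour: the step of a 1.5-fold higher number from compound 1 to compound 3 (0.17 log units; within the scatter) and the step of a 1.7-fold lower number from compound 2 to compound 3 (0.22 log units; within the scatter) both sit inside the usual scatter. For the measured compounds named here, only the step of a 2.5-fold higher number from compound 1 to compound 2 (0.39 log units; beyond the scatter) goes beyond it, so the 4-fluorophenyl compound carries the one number that stands apart.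

Compound 4 `O=C(CCCCCCNC(=O)C(O)(O)C(F)(F)F)Nc1ccc(F)cc1F` has not been measured. It differs from compound 3 in one place: 2,4-difluorophenyl in place of 4-methoxyphenyl on an amide-type nitrogen. The step that bears most directly on it is a 1.7-fold lower number from compound 2 to compound 3 (0.22 log units; within the scatter), run in the opposite direction, which would move the number back toward that of compound 2. Going by the values given here, the second fluorine has no counterpart among the measured compounds, so its weight is unknown. In this assay compound 4 is therefore expected to sit close to compound 2, a step of a 1.5-fold higher number from compound 3 to compound 4 (0.19 log units; within the scatter) upward. The estimate for compound 4 is 7000 nM, in a range from 3000 nM to 16000 nM.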

Compound 4, half-maximal inhibitory concentration: 18500 nM
Compound 4: the middle estimate sits 2.6-fold (0.42 log units) below what was measured; measured number outside the range, above it.
By their numbers in this assay, from the lowest: compounds 1, 3 and 2 (each within the scatter of the next, the first and the last beyond it); then compound 4.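

In this assay, for the compounds shown here, fluoro in place of hydrogen on an aromatic carbon is not a silent change: a 2.4-fold higher number from compound 2 to compound 4 (0.39 log units; beyond the scatter) lies beyond the scatter, which is the first sign that a second ring substituent on this amide-type nitrogen's aryl group can shift the number. The 2,4-difluorophenyl group also stands apart from the other two aryl groups, with a 4.1-fold higher number from compound 3 to compound 4 (0.61 log units; beyond the scatter) and a 6.0-fold higher number from compound 1 to compound 4 (0.78 log units; beyond the scatter), so compound 4 is the weakest inhibitor of the four, its steps to all the others being beyond the scatter. Nothing available here accounts for this shift.

Open, going by these compounds, is whether a chloro or methyl group on the same aromatic carbon would give a step like that of the second fluoro. Also open, on these data alone, is whether the step persists with a shorter or longer chain in the shared core.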